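The compounds below may be only part of what the source reports. "The series", "measured", "known", "first", "only" and "open" are said of these compounds alone.

Measured compounds:
compound 1 `CCCNc1cccnc1-c1ccc(C(=O)Nc2ccc(C(C)(C)C)cc2)cc1`: 37 nM
compound 2 `CN(C)Cc1cccnc1-c1ccc(C(=O)Nc2ccc(C(C)(C)C)cc2)cc1`: 234 nM
compound 3 `CC(C)(C)c1ccc(NC(=O)c2ccc(-c3ncccc3-c3ncc[nH]3)cc2)cc1`: 694 nM

All three share one core and differ only in the group fixed to the pyridine-type ring. In a functional assay for antagonist activity at transient receptor potential cation channel subfamily V member 1 (Rattus norvegicus) (a higher number here means a weaker inhibitor, a lower number a stronger inhibitor), compound 3 gives the highest number of the three: compound 2 sits a 3.0-fold higher number from compound 2 to compound 3 (0.47 log units; beyond the scatter) below it, and compound 1 further still, a 19-fold higher number from compound 1 to compound 3 (1.27 log units; beyond the scatter). Compound 4 `CC(C)(C)c1ccc(NC(=O)c2ccc(-c3ncccc3-c3nnco3)cc2)cc1` continues this series with a fresh swap at the same position: 1,3,4-oxadiazol-2-yl in place of 1H-imidazol-2-yl on an aromatic carbon. The oxadiazole brings no donor and more acceptors than the imidazole it replaces.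

Among the compounds with values here, no measured step matches this exact swap. Within the data shown here, what the earlier steps show is that changes here move this assay by modest to large amounts, as in a 6.3-fold higher number from compound 1 to compound 2 (0.80 log units; beyond the scatter) and a 19-fold higher number from compound 1 to compound 3 (1.27 log units; beyond the scatter), with no simple rule in sight: the donor-bearing propylamino of compound 1 was best, yet the donor-bearing imidazole of compound 3 was worst. For compound 4 the expected outcome is therefore a number close to that of compound 3, with a broad range either way, and a step of a 1.2-fold higher number from compound 3 to compound 4 (0.06 log units; within the scatter) is estimated. Compound 4 is estimated at 800 nM, within 250 nM to 2500 nM.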

Compound 4, half-maximal inhibitory concentration: 59 nM
Estimate against measurement, compound 4: 14-fold (1.13 log units) above; measured number below the stated range.
By their numbers in this assay, from the lowest: compounds 1 and 4 (each within the scatter of the next); then compound 2; then compound 3.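

Replacing 1H-imidazol-2-yl with 1,3,4-oxadiazol-2-yl keeps a five-membered aromatic ring of 5 heavy atoms, yet this assay records a 12-fold lower number from compound 3 to compound 4 (1.07 log units; beyond the scatter) and so shows that the make-up of such a ring at this position matters, not only its size. The same ring also compares well with the (dimethylamino)methyl group, with a 4.0-fold lower number from compound 2 to compound 4 (0.60 log units; beyond the scatter) on that swap, while the comparison with propylamino gives a 1.6-fold higher number from compound 1 to compound 4 (0.20 log units; within the scatter) and leaves those two compounds level. With 0 hydrogen-bond donors on the oxadiazole, a donor in this group is clearly not needed for a low number, which neither compound 1 nor compound 3 could show. No measurement at hand explains why the imidazole and the oxadiazole differ so much.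

Going by these compounds, it remains open whether the oxygen of the ring or the placing of its nitrogens accounts for the step. An oxazole or a 1,2,4-oxadiazole at this position would help separate those two readings.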